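This account rests on a few compounds, and the source may have more. Where it says the series, first, only, none or still open, it means among the compounds named here.

Two compounds have numbers in an assay on isolated protein for binding affinity to leukotriene B4 receptor 1 (Homo sapiens), tested at 1 uM (a higher number here means more inhibition at the concentration tested (going by the name of the read-out), a lower number less inhibition), so far. Compound 1 `C=CCc1cc(C(C)=O)c(O)cc1OCCCCCCCCCCC#N` gives 14% in this assay, and compound 2 `CCc1cc(C(C)=O)c(O)cc1OCCCCCCC(C)(C)C#N` gives 30%. Compound 2 therefore stands highest of the two, with compound 1 lower by a difference that lies beyond the usual scatter. Compound 3 `CCc1cc(C(C)=O)c(O)cc1OCCCCCn1cncn1` has not yet been measured in this assay. It differs from compound 2 in one place: 1H-1,2,4-triazol-1-yl in place of 2-cyano-2-methylpropyl on a saturated chain carbon, five bonds along the chain from an oxygen on an aromatic ring. Going by the values given here, no measured pair shows this kind of change, so the expected step of a number 10 percentage points lower from compound 2 to compound 3 (within the scatter) is a small loss, barely beyond the scatter. Compound 3 is thus estimated at 20%, within a range of 5% to 38%.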

Compound 3, a percentage reported as inhibition, at one concentration (the size of the read-out at that concentration, not a potency): 30%
Compound 3: the middle estimate sits 10 percentage points below what was measured; the measured number falls inside the stated range.
By their numbers in this assay, from the lowest: compound 1; then compounds 2 and 3 (each within the scatter of the next).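

The step of no change at the digits printed from compound 2 to compound 3 (within the scatter) in this assay comes with 1H-1,2,4-triazol-1-yl in place of 2-cyano-2-methylpropyl, so this chain position accepts a five-membered aromatic ring in place of an open-chain nitrile group with no change beyond the scatter. Going by these compounds alone, this is the first reading of a change at this position, and it holds for this one pair only. Nothing available accounts for the result. Still open, from the compounds shown here alone, is whether an amine or a carboxylic acid at this place would read the same, and what a longer chain carrying the 1H-1,2,4-triazol-1-yl group would give.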